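The source may report more compounds than this note shows. Statements on the series, on what has been measured and on what is new or still open speak of the compounds shown alone.

Measured so far in a functional assay on the whole organism (B cells) with Mus musculus as the target; on this read-out higher numbers stand for larger maximal responses and lower numbers for smaller maximal responses:
compound 1 `Nc1nc(O)c2c(n1)n(C1OC(CO)[C@@H](O)[C@H]1O)c(=O)n2C/C=C/c1ccccc1` gives 73%
compound 2 `C=CCn1c(=O)n(C2CN(CCCC)CC(CO)O2)c2nc(N)nc(O)c21` gives 38%
compound 3 `C=CCn1c(=O)n([C@@H]2O[C@H](CO)[C@H]3OC(CCC)(CCC)O[C@H]32)c2nc(N)nc(O)c21` gives 123%

Compound 1 stands second highest of the three numbers. Its nearest neighbour is compound 2, whose number lies lower by a gap beyond the usual scatter; its furthest is compound 3, whose number lies higher, again beyond the scatter. Among the compounds with values here, the three measured compounds differ from one another in more than one place, so no single step between measured compounds can be read off, and none of them carries the change now under consideration.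

Compound 4 `N#Cc1ccc(Cn2c(=O)n(C3OC(CO)[C@@H](O)[C@H]3O)c3nc(N)nc(O)c32)cc1` has not yet been measured in this assay. From compound 1 it differs as follows: 4-cyanophenyl in place of 2-phenylethenyl on a saturated chain carbon bound to an aromatic nitrogen. Within the data shown here, no measured pair shows what this change does on this read-out, so the expectation rests on compound 1 alone and is held close to its value, with a wide range to reflect the absence of any comparison. Compound 4 is expected at 68%, within 35% to 105%. This estimate means an expected step of a number 5 percentage points lower from compound 1 to compound 4 (within the scatter), which is expected to stay within the scatter rather than beyond it in either direction.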

Compound 4, largest response reached (reported as maximal response), in percent of the reference or control that the assay uses: 50%
Compound 4: middle estimate off by 18 percentage points, on the high side; measured number inside the range.
By their numbers in this assay, from the lowest: compound 2; then compound 4; then compound 1; then compound 3.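

Within the data shown here, replacing 2-phenylethenyl with 4-cyanophenyl on a saturated chain carbon bound to an aromatic nitrogen gives the first single-place comparison: in this assay it amounts to a number 23 percentage points lower from compound 1 to compound 4 (beyond the scatter). The two groups have the same heavy-atom count and each holds one six-membered aromatic ring of carbon only, so these shared features do not keep the maximal response unchanged at this place; they differ in a double bond against a triple bond and in the hydrogen-bond acceptor that enters with the nitrile. No measurement at hand accounts for the step.

One pair cannot separate the loss of the double bond from the arrival of the nitrile, and a plain benzyl group at this place would be the comparison that divides the two. Also open, from the compounds shown here alone, are whether an amine or a carboxylic acid on the same ring in place of the nitrile would move the response differently, and whether this change keeps its size on the rest of compound 2 or compound 3.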